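This account rests on a few compounds, and the source may have more. Where it says the series, first, only, none or still open, it means among the compounds named here.

Measured compounds:
- compound 1 `O=C(Nc1cccc(-n2cc(-c3ccncc3)c(-c3cc(O)cc(Cl)c3)n2)c1)Nc1ccc(Cl)c(C(F)(F)F)c1` gives 91%
- compound 2 `O=C(Nc1cccc(-n2cc(-c3ccncc3)c(-c3cc(O)cc(Cl)c3)n2)c1)Nc1ccc(Cl)c(Cl)c1` gives 82%

In a functional assay on HCT-116 cells (Homo sapiens) for inhibition, read by sulforhodamine B assay, with a stated time of 48 h, tested at 1 uM (on this read-out higher numbers stand for a weaker effect at the one concentration tested and lower numbers for a stronger effect), compound 1 has the highest of the two numbers, meaning the weaker effect of the pair at the single concentration tested. Its nearest neighbour is compound 2, reached by a single change, chloro in place of trifluoromethyl on an aromatic carbon, and that step, a number 9 percentage points lower from compound 1 to compound 2 (within the scatter), stays within the scatter, so the two compounds cannot be told apart.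

Compound 3 `COc1cc(Cl)cc(-c2nn(-c3cccc(NC(=O)Nc4ccc(Cl)c(C(F)(F)F)c4)c3)cc2-c2ccncc2)c1` is not yet measured. It differs from compound 1 as follows: methyl in place of hydrogen on an oxygen on an aromatic ring. Among the measured compounds shown here, no measured step touches this oxygen on the aromatic ring; the only step known, from compound 1 to compound 2, changes a different group and was small. There is therefore no basis for expecting a step beyond the scatter in this assay. For compound 3 a value of about 88% is estimated, with a range from 70% to 100%. The step this implies, a number 3 percentage points lower from compound 1 to compound 3 (within the scatter), is expected to be small.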

Compound 3, a percentage reported as activity, at one concentration (the size of the read-out at that concentration, not a potency): 38%
For compound 3 the middle estimate is 50 percentage points above the measured one; the measured number lies below the stated range.
By their numbers in this assay, from the lowest: compound 3; then compounds 2 and 1 (each within the scatter of the next).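

In this assay, replacing hydroxy with methoxy on the 3-chloro-5-hydroxyphenyl group gives a number 53 percentage points lower from compound 1 to compound 3 (beyond the scatter), which on this read-out means a stronger effect at the one concentration tested. Among the compounds shown here, this oxygen is therefore a place where a methyl, a single added heavy atom, moves the result beyond the scatter, something the only earlier step, a number 9 percentage points lower from compound 1 to compound 2 (within the scatter), made at a different place on the molecule, did not show. Nothing measured here explains why this change has so large an effect.

As far as these compounds go, it remains open whether a longer chain on this oxygen, such as ethoxy, or an amine in place of the hydroxy would give a similar result. From the compounds shown here alone, it is also open whether the same methyl on the oxygen of compound 2 would produce a step of similar size.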